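A single stereocentre change at the assay limit

The source may report more compounds than this note shows. Statements on the series, on what has been measured and on what is new or still open speak of the compounds shown alone.

Measured in a functional assay on A549 cells (Homo sapiens) for cytotoxicity, read by MTT assay, with a stated time of 24 h (on this read-out higher numbers stand for weaker inhibition and lower numbers for stronger inhibition), both values being limits:
- compound 1 `CC(C)c1cc2c(cc1O)[C@]13CCC[C@](C)(CO[C@@H]1O)[C@@H]3CC2`: > 10000 nM
- compound 2 `CO[C@@H]1OC[C@@]2(C)CCC[C@@]13c1cc(O)c(C(C)C)cc1CC[C@@H]23`: > 10000 nM

The measurements so far show (the limit of > 10000 nM in this assay, at which 2 of the 2 values shown sit). Compound 2 stands at a limit of this assay, reported as > 10000 nM, and not at a numerical value.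

Compound 3 `CO[C@H]1OC[C@@]2(C)CCC[C@@]13c1cc(O)c(C(C)C)cc1CC[C@@H]23` has not yet been measured. It is related to compound 2 by a single change: the two compounds have the same atoms and bonds and differ only in configuration as drawn: 1 of 4 stereo elements differ; a stereocentre at a saturated ring carbon is drawn R in compound 2 and S in compound 3. For the measured compounds named here, with no measured step to draw on, no change beyond the usual scatter is expected, and no direction can be given. The estimated outcome is a step that the limit leaves unreadable from compound 2 to compound 3. This expectation rests on compound 2 and its limit of > 10000 nM. A further limit is the likely report. For compound 3 the expected value is 20000 nM, within an estimated range of 10000 nM to 50000 nM.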

Compound 3, half-maximal inhibitory concentration: > 10000 nM
Compound 3: no number, only a limit; the forecaster's own chance of this, stated with the estimate: 90%; the middle value lies beyond the limit too.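

Compound 3 also returned only a limit, so neither the step from compound 2 to compound 3 nor the step from compound 1 to compound 3 can be read. The compounds shown leave open whether either change, the stereocentre or the methyl in place of hydrogen, affects cytotoxicity at all.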